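The compounds below may be only part of what the source reports. "The series", "measured", "known", "first", "only" and "open" are said of these compounds alone.

In a toxicity assay on NIH3T3 cells (Mus musculus) for cytotoxicity, read by resazurin assay (a higher number here means that more compound is needed for the effect, a lower number that less compound is needed), three compounds have been measured so far, and none has yet given a number. Compound 1 `N#Cc1ccc(NCc2cncn2Cc2ccc(-c3ccccc3)cc2)cc1-c1ccccc1` gives > 1000 nM, which is a limit of the assay. Compound 2 `O=C(OC1CCCCC1)c1ccc(NCc2cncn2Cc2ccc(-c3ccccc3)cc2)cc1-c1ccccc1` gives > 10000 nM, which is also a limit. Compound 3 `c1ccc(-c2ccc(Cn3cncc3CNc3ccc(-c4cncs4)c(-c4ccccc4)c3)cc2)cc1` gives > 1000 nM, again a limit, so it stands with the limit of > 1000 nM in this assay, at which 2 of the 3 values shown sit.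

Compound 4 `c1ccc(-c2ccc(Cn3cncc3CNc3ccc(-c4ccc[nH]4)c(-c4ccccc4)c3)cc2)cc1` keeps the core of compound 3 and alters one group: 1H-pyrrol-2-yl in place of 1,3-thiazol-5-yl on an aromatic carbon. Within the data shown here, three measured steps concern the same aromatic carbon: a step that the two limits leave unreadable from compound 1 to compound 3, a step that the two limits leave unreadable from compound 2 to compound 3 and a step that the two limits leave unreadable from compound 1 to compound 2. None of them has a readable size, so they offer no measured effect of a change at this place, in either direction. Among the measured compounds shown here, the only guide is that nitrile, cyclohexyloxycarbonyl and 1,3-thiazol-5-yl all leave the compounds at limits. In this assay, therefore, no step beyond the scatter is expected, and no direction can be given. The expectation rests on compound 3, whose reading of > 1000 nM is a limit and not a number. The estimate amounts to an expected step that the limit leaves unreadable from compound 3 to compound 4. Compound 4 is estimated at 3000 nM, with an expected range from 800 nM to 15000 nM.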

Compound 4, half-maximal effective concentration: > 10000 nM
Compound 4: no number, only a limit (the forecaster's own chance of this, stated with the estimate: 80%); middle value at least 3.3-fold (0.52 log units) away from the limit.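

In this assay compound 4 gives > 10000 nM, which is a limit and not a number, so no step can be read between it and compound 1, compound 2 or compound 3. The compounds shown leave open what concentration of any of them gives the effect in this assay, and whether the group on this aromatic carbon changes that concentration at all.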